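Amide variation at the aryl carbonyl: compound 2 to compound 4

A few compounds are considered here, and "the series" means these few. Any claim that something is new, unique, unknown or untested is made for them only; others in the source may bear on it.

Of the compounds shown here, three of the shared core have been measured in a functional assay on HT-29 cells (Homo sapiens); a lower number here means that less compound is needed, a higher number that more compound is needed for the effect. Compound 1 `CC(=O)Nc1cccc(-c2cc(C(=O)N[C@H]3CCCNC3)c(NC(N)=O)s2)c1` gives 1800 nM. Compound 2 `NC(=O)Nc1sc(-c2ccc(C(=O)N3CCOCC3)cc2)cc1C(=O)N[C@H]1CCCNC1` gives 610 nM, and compound 3 `NC(=O)Nc1sc(-c2ccc(CN3CCCCC3)cc2)cc1C(N)=O` gives 270 nM. Among these three numbers compound 2 stands second highest: compound 3 lies nearest, at a lower number by a gap beyond the scatter, and compound 1 lies furthest, at a higher number by a gap beyond the scatter.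

Compound 4 `CN(C)C(=O)c1ccc(-c2cc(C(=O)N[C@H]3CCCNC3)c(NC(N)=O)s2)cc1` has not yet been measured. It differs from compound 2 in one place: dimethylamino in place of morpholin-4-yl on a carbonyl carbon. Among the compounds with values here, no step between measured compounds touches this position, and the numbers in hand say nothing about it. The rest of the molecule is unchanged, so a step of no more than the usual scatter is expected in this assay, without a clear direction. Compound 4 is therefore estimated at 550 nM, with a range from 200 nM to 1500 nM. In this assay the step expected is a 1.1-fold lower number from compound 2 to compound 4 (0.04 log units; within the scatter).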

Compound 4, half-maximal effective concentration: 320 nM
Estimate against measurement, compound 4: 1.7-fold (0.24 log units) above, and the stated range covers the measured number.
By their numbers in this assay, from the lowest: compounds 3, 4 and 2 (each within the scatter of the next, the first and the last beyond it); then compound 1.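

Dimethylamino in place of morpholin-4-yl on a carbonyl carbon gives a 1.9-fold lower number from compound 2 to compound 4 (0.28 log units; within the scatter) in this assay and provides the first reading at this position, which none of the earlier compounds touched. The morpholin-4-yl ring and its oxygen are therefore not required for a number in this range, and the smaller dimethylcarbamoyl group serves equally well within the scatter. No measurement in hand offers an explanation for the size of this step.

Still open, from the compounds shown here alone, is whether a carboxylic acid, an unsubstituted carboxamide, a piperazine amide or an amide with a longer alkyl chain on this carbonyl would stay in the same range. Within the data shown here, this exchange also has only one reading, so whether it behaves alike with other groups elsewhere on the shared core remains unknown.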